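The source may hold more compounds than are shown below. What is called first, only, known or untested is meant among the compounds shown, and "the series" means these compounds.

Working notes on the series.

Compound 1 `COc1cc(/C=C2\CN(C)C/C(=C\c3ccc(Cl)cc3)C2=O)cc(OC)c1` carries a chloro group on one of its aromatic rings, and in an ADME assay on L02 cells (Homo sapiens) for cytotoxicity, read by MTT assay, with a stated time of 24 h (a higher number here means a weaker inhibitor, a lower number a stronger inhibitor), compound 1 gives 18900 nM. Compound 2 `COc1cc(/C=C2\CN(C)C/C(=C\c3ccc(Br)cc3)C2=O)cc(OC)c1` differs from compound 1 in one place only: bromo in place of chloro on an aromatic carbon. In this assay compound 2 gives 21300 nM. For this pair the measured step is a 1.1-fold higher number from compound 1 to compound 2 (0.05 log units; within the scatter), so the exchange of halogen leaves the read-out essentially where it was.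

Compound 3 `CN1C/C(=C\c2ccc(Cl)cc2)C(=O)/C(=C/c2ccc(C#N)cc2)C1` is built on a different core; how the core of compound 3 differs from the core of compound 1 is not broken down here. In this assay compound 3 gives 16200 nM, a number that lies within the scatter of both compound 1 and compound 2, so the three measured compounds cannot be told apart on this read-out.

Compound 4 `CN1C/C(=C\c2ccc(Br)cc2)C(=O)/C(=C/c2ccc(C#N)cc2)C1` stands to compound 3 exactly as compound 2 stands to compound 1: bromo in place of chloro on an aromatic carbon. The place of the change is described in the same words for both pairs, so this is the same change carried onto the core of compound 3. The step from compound 3 to compound 4 in this assay is therefore expected to be small, a 1.1-fold higher number from compound 3 to compound 4 (0.03 log units; within the scatter), which rests on compound 1 and compound 2 because a 1.1-fold higher number from compound 1 to compound 2 (0.05 log units; within the scatter) stayed within the scatter. For compound 4 the expected value in this assay is 17500 nM, with a likely range from 9000 nM to 35000 nM.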

Compound 4, half-maximal inhibitory concentration: 10500 nM
Beside the measured number, compound 4's estimate is 1.7-fold (0.22 log units) above it, within the range that was stated.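

In this assay, bromo in place of chloro on the core of compound 3 gives a 1.5-fold lower number from compound 3 to compound 4 (0.19 log units; within the scatter), so this exchange again stays within the usual scatter of repeated measurements. Set beside the same exchange on the core of compound 1, the new step does not differ from the earlier one: the same change on two cores in this assay, a 1.1-fold higher number (0.05 log units; within the scatter) from compound 1 to compound 2 and a 1.5-fold lower number (0.19 log units; within the scatter) from compound 3 to compound 4, 1.7-fold (0.24 log units) apart, within the scatter of two such steps This shows that, on these two cores, going from 4-chlorophenyl to 4-bromophenyl leaves the read-out indistinguishable from that of the chloro parent, and the differing signs of the two steps should not be read as a real dependence on the core; it does not show that the change would behave the same way on any other core, since the comparison rests on two pairs and one read-out, and steps this small cannot establish that the two cores respond identically.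

The compounds shown leave open whether anything other than a halogen at this place, such as an amine, a carboxylic acid or a longer alkyl chain, would move the number beyond the scatter. They also leave open whether fluoro or iodo in the same place would behave as chloro and bromo do here.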